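Methoxy to cyclohexylamino at the carbonyl: series notes

The compounds below may be only part of what the source reports. "The series", "measured", "known", "first", "only" and "open" are said of these compounds alone.

Compound 1 `COC(=O)c1nc(Br)c2cccnc2c1N[C@H]1CC[C@H](N)CC1` is the reference point. In a functional assay on MDA-MB-435 cells (Homo sapiens) for cytotoxicity, read by MTT assay, with a stated time of 72 h (on this read-out lower numbers stand for stronger inhibition and higher numbers for weaker inhibition), compound 1 gives > 20000 nM, which is a limit of the assay and not a number. Among the compounds with values here, compound 2 `O=C(NCCCNc1c(C(=O)NCc2ccc(F)cc2)nc(Br)c2cccnc12)c1ccccc1` is the only other compound with data. In this assay compound 2 gives > 20000 nM, again a limit rather than a number. Both results sit at the limit of > 20000 nM in this assay, at which 2 of the 2 values shown sit, so compound 1 stands at the limit together with compound 2 and no order between them can be drawn. Compound 3 `N[C@H]1CC[C@H](Nc2c(C(=O)NC3CCCCC3)nc(Br)c3cccnc23)CC1` is not yet measured. Relative to compound 1 the change is cyclohexylamino in place of methoxy on a carbonyl carbon. Within the data shown here, no step between measured compounds is available, so the size of this change is unknown from the series itself. The step of an at least 1.3-fold lower number from compound 1 to compound 3 (0.12 log units; that floor lies within the scatter) is expected to be small or none beyond the scatter. Compound 3 is accordingly expected to give about 15000 nM in this assay, within a range from 3000 nM to 60000 nM, quite possibly reported again only as a limit.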

Compound 3, half-maximal inhibitory concentration: > 10000 nM
Compound 3: no number, only a limit (the forecaster's own chance of this, stated with the estimate: 60%); the middle value is on the limit's open side.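

In this assay compound 3 gives > 10000 nM, a limit and not a number. Within the data shown here, compound 1 gives > 20000 nM, also a limit, so no step from compound 1 to compound 3 can be read. The compounds shown leave open what cyclohexylamino in place of methoxy on a carbonyl carbon does to this read-out.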